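A Single Fluorine Added to an Aromatic Ring

The source may hold more compounds than are shown below. What is called first, only, known or untested is meant among the compounds shown, and "the series" means these compounds.

In a functional assay on HBL-100 cells (Homo sapiens) for inhibition, read by sulforhodamine B assay, with a stated time of 48 h (on this read-out lower numbers stand for stronger inhibition of growth and higher numbers for weaker inhibition of growth), two compounds have been measured so far. Compound 1 `O=C(/C(=C/C1CCCCC1)CCl)c1ccccc1` gives 22000 nM. Compound 2 `C=C(C/C(=C\c1ccccc1)C(=O)c1ccccc1)C(=O)c1ccccc1` gives 10000 nM, the lower of the two numbers; its gap to compound 1 lies beyond the usual scatter of repeated measurements, so compound 2 stands as the stronger growth inhibitor of the pair. Compound 3 `C=C(C/C(=C\c1ccccc1F)C(=O)c1ccccc1)C(=O)c1ccccc1` has not yet been measured in this assay. It differs from compound 2 in one place: fluoro in place of hydrogen on an aromatic carbon. Going by the values given here, no pair of measured compounds shows such a change, so the data give no direct guide to how one added fluorine shifts the read-out. A small step is expected, in either direction, not beyond the scatter: a 1.1-fold lower number from compound 2 to compound 3 (0.05 log units; within the scatter). Compound 3 is therefore estimated to give about 9000 nM, within a range from 4000 nM to 20000 nM.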

Compound 3, concentration for 50% growth inhibition: 15000 nM
Beside the measured number, compound 3's estimate is 1.7-fold (0.22 log units) below it, and the stated range covers the measured number.
By their numbers in this assay, from the lowest: compounds 2, 3 and 1 (each within the scatter of the next, the first and the last beyond it).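

In this assay, going by these compounds alone, this change gives a 1.5-fold higher number from compound 2 to compound 3 (0.18 log units; within the scatter) and so offers the first direct look at adding fluorine to these compounds. On an aromatic carbon ortho to a large group, the step from phenyl to 2-fluorophenyl cannot be told apart from the ordinary variation between repeated measurements. This is a single pair, so it describes only this one place on the shared core and supports no general rule about fluorine, and no measurement at hand offers an explanation for the result.

Still open, on these data alone, is whether a chlorine atom, a methoxy group or an amine at this same place would give a step that clearly exceeds that variation. As far as these compounds go, the effect of fluoro on other carbons of this ring, or on the other aromatic rings, also remains open.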